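A few compounds are considered here, and "the series" means these few. Any claim that something is new, unique, unknown or untested is made for them only; others in the source may bear on it.

Compound 3, with the structure `Cc1cc(C)c2cccc(OCc3c(Cl)ccc(S(=O)(=O)NC4(C(=O)N5CCN(C(=O)C[C@@H](N)CCCN)CC5)CCCC4)c3Cl)c2n1`, sits in an assay on isolated protein for binding affinity to B1 bradykinin receptor (Homo sapiens) (a higher number here means a weaker inhibitor, a lower number a stronger inhibitor), at a limit rather than a number. In this assay compound 3 gives < 10000 nM, which is a limit of the measurement. Compound 1, with the structure `Cc1cc(C)c2cccc(OCc3c(Cl)ccc(S(=O)(=O)NC4(C(=O)N5CCN(C(=O)[C@@H](N)CCCC[N+](C)(C)C)CC5)CCCC4)c3Cl)c2n1`, is also known only as a limit. In this assay compound 1 gives < 10000 nM, a limit. Compound 2, with the structure `Cc1cc(C)c2cccc(OCc3c(Cl)ccc(S(=O)(=O)NC4(C(=O)N5CCN(C(=O)CCCCC[N+](C)(C)C)CC5)CCCC4)c3Cl)c2n1`, shows the same kind of result. In this assay compound 2 gives < 10000 nM, again a limit.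

Compound 4, with the structure `Cc1cc(C)c2cccc(OCc3c(Cl)ccc(S(=O)(=O)NC4(C(=O)N5CCN(C(=O)[C@@H](N)CCC[N+](C)(C)C)CC5)CCCC4)c3Cl)c2n1`, is not yet measured. It differs from compound 3 by a group of 9 heavy atoms (7 carbon, 2 nitrogen; no ring) in place of a group of 7 heavy atoms (5 carbon, 2 nitrogen; no ring), on a carbonyl carbon. The steps already measured around this change are a step that the two limits leave unreadable from compound 1 to compound 3 and a step that the two limits leave unreadable from compound 2 to compound 3, and also a step that the two limits leave unreadable from compound 1 to compound 2. None of them has a readable size, because the limit of < 10000 nM in this assay, at which 3 of the 3 values shown sit, holds all three values. No direction can therefore be read for the change to compound 4, and the expectation for this assay can only be that compound 4 lands where the others do. Compound 4 is expected to give about 3000 nM, within a range from 300 nM to 10000 nM. The step from compound 3 that this estimate means is expected to be a step that the limit leaves unreadable from compound 3 to compound 4.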

Compound 4, inhibition constant: < 10000 nM
Compound 4 ended at the assay's limit (the forecaster's own chance of this, stated with the estimate: 70%); the middle value does not contradict the limit.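

In this assay, no step between compound 4 and compound 1, compound 2 or compound 3 can be read, because all four compounds share one limit: the limit of < 10000 nM in this assay, at which 4 of the 4 values shown sit.

The compounds shown leave open how strongly each of the four binds, and whether replacing the 2,5-diaminopentyl group of compound 3 with the group carrying a net charge of +1 in compound 4 changes binding at all.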